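Side-chain steps in a small series of benzyl amides

The source may hold more compounds than are shown below. What is called first, only, known or untested is meant among the compounds shown, and "the series" means these compounds.

Compound 1 `CCC(O)Cc1cn(CC(=O)NCc2ccccc2)nn1`: 630 uM
Compound 2 `CC(C)(O)c1cn(CC(=O)NCc2ccccc2)nn1`: 1600 uM

Among the measured compounds shown here, in an ADME assay on cells (spleen, Mus musculus, strain C57BL/6) for inhibition, read by flow cytometry and propidium iodide staining, with a stated time of 24 h, at 37 degrees C (on this read-out higher numbers stand for an effect only at larger amounts of compound and lower numbers for an effect already at smaller amounts), compound 1 gives 630 uM, the lower of the two numbers so far. For the measured compounds named here, the only measured step, a 2.5-fold higher number from compound 1 to compound 2 (0.40 log units; beyond the scatter), is modest but lies beyond the scatter.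

Compound 3 `CC(C)(C)OC(=O)NCc1cn(CC(=O)NCc2ccccc2)nn1` has not yet been measured. Its difference from compound 1 is (tert-butoxycarbonyl)amino in place of 1-hydroxypropyl on a saturated chain carbon bound to an aromatic carbon. The group enters on a saturated chain carbon bound to an aromatic carbon, whereas the measured step replaces a group on an aromatic carbon. Going by the values given here, no measured compound carries (tert-butoxycarbonyl)amino. The step of a 2.5-fold higher number from compound 1 to compound 2 (0.40 log units; beyond the scatter) therefore gives only a rough sense of size and no direction for this change. On that thin basis, no step beyond the scatter is expected in this assay, and neither direction is favoured. The expected value for compound 3 is 500 uM, with an estimated range of 160 uM to 1600 uM. The estimated step is a 1.3-fold lower number from compound 1 to compound 3 (0.10 log units; within the scatter).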

Compound 3, concentration for half-maximal effect: > 2000 uM
Compound 3 ended at the assay's limit (the forecaster's own chance of this, stated with the estimate: 15%); at least 4.0-fold (0.60 log units) between middle value and limit.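

In this assay compound 3 gives > 2000 uM, which is a limit of the assay and not a number. Among the compounds shown here, this is the first change on a saturated chain carbon bound to an aromatic carbon, and it supplies the direction that the earlier pair could not: (tert-butoxycarbonyl)amino in place of 1-hydroxypropyl brings an at least 3.1-fold higher number from compound 1 to compound 3 (0.50 log units; beyond the scatter), so that compound 1 keeps the lowest number of the three. Both changes away from compound 1 now raise the number, each at a different place and each resting on a single pair, and the size of this latest step has no upper end, as the reading stops at the top of the range: the limit of > 2000 uM in this assay, at which 1 of the 3 values shown sits.

On these data alone, it remains open whether the rise belongs to the (tert-butoxycarbonyl)amino group as a whole or to part of it, and a free primary amine on the same saturated chain carbon would help to separate the two. A carboxylic acid or a longer alkyl chain on that carbon would show whether any group there can lower the number relative to compound 1 in this assay.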